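Swapping methylcarbamoyl for methylsulfanyl on a saturated ring carbon

The source may hold more compounds than are shown below. What is called first, only, known or untested is meant among the compounds shown, and "the series" means these compounds.

Compound 1 (`CC(=O)C1(c2cc(F)cc(OCc3ccc(-n4ccnc4C)cc3)c2)CCOCC1`) and compound 2 (`CNC(=O)C1(c2cc(F)cc(OCc3ccc(-n4ccnc4C)cc3)c2)CCOCC1`) share one core and differ only on a carbonyl carbon. In a functional assay on the whole organism for activation, with Mus musculus as the target (on this read-out lower numbers stand for an effect already at smaller amounts and higher numbers for an effect only at larger amounts of compound), compound 1 gives 12 mg/kg as its dose, and compound 2 gives 13 mg/kg as its dose, so compound 2 stands level with compound 1 within the scatter. Going on to compound 3 (`CSC1(c2cc(F)cc(OCc3ccc(-n4ccnc4C)cc3)c2)CCOCC1`), methylsulfanyl takes the place of methylcarbamoyl on a saturated ring carbon (methylsulfanyl in place of methylcarbamoyl on a saturated ring carbon). Among the compounds with values here, only one measured step bears on this change. That step (a 1.1-fold higher number from compound 1 to compound 2 (0.03 log units; within the scatter)) put methylamino in place of methyl on a carbonyl carbon and stayed within the scatter. Both of its compounds keep the carbonyl, however, and compound 3 has none, so the guidance is indirect. Within the data shown here, no measured pair shows what losing the carbonyl does. On these data alone, no step beyond the scatter is therefore expected in this assay, and the direction remains open. The estimated step (a 1.2-fold higher number from compound 2 to compound 3 (0.06 log units; within the scatter)) is accordingly small, with wide uncertainty. For compound 3 the expected dose is 15 mg/kg as a central estimate, with an expected range from 6 mg/kg to 38 mg/kg on this read-out.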

Compound 3, dose for half-maximal effect: 5 mg/kg
The estimate for compound 3 lay 3.0-fold (0.48 log units) above the measured number; the whole stated range lies above it.
By their numbers in this assay, from the lowest: compound 3; then compounds 1 and 2 (each within the scatter of the next).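

In this assay the group on this saturated ring carbon proves able to move the dose: methylsulfanyl in place of methylcarbamoyl gives a 2.6-fold lower number from compound 2 to compound 3 (0.41 log units; beyond the scatter) and methylsulfanyl in place of acetyl gives a 2.4-fold lower number from compound 1 to compound 3 (0.38 log units; beyond the scatter) as a second modest step beyond the scatter. The earlier pair had changed only what sits on the carbonyl carbon and gave a 1.1-fold higher number from compound 1 to compound 2 (0.03 log units; within the scatter) with the carbonyl kept, whereas both new steps remove the carbonyl and bring in sulfur, and compound 3 acts at a smaller dose than either carbonyl compound. Nothing available gives a measured reason for this shift. 

The two steps cannot separate the loss of the carbonyl from the arrival of the sulfur, and a methoxy group on the same ring carbon would be the direct test of whether the sulfur atom itself counts. On these data alone, it also remains open whether the lower number would survive a longer chain on the sulfur, such as ethylsulfanyl, or a methylsulfonyl group in the same place.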